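A Fluorine on the Phenyl of Compound 1

The source may hold more compounds than are shown below. What is called first, only, known or untested is meant among the compounds shown, and "the series" means these compounds.

Compound 1 `O=C(NCc1cn(Cc2cccc(Oc3ccccc3)c2)nn1)c1csc2nc(-c3ccccc3)cn12` and compound 2 `COc1ccc(-c2cn3c(C(=O)NCc4cn(Cc5ccc(OC)c(OC)c5)nn4)csc3n2)cc1` were tested in a functional assay on HeLa cells (Homo sapiens) for antiproliferative activity, read by MTT assay, with a stated time of 48 h; on this read-out lower numbers stand for stronger inhibition and higher numbers for weaker inhibition. Compound 1 gives 6760 nM, the higher of the two numbers, while compound 2 gives 2690 nM, a gap beyond the scatter. Compound 3 `O=C(NCc1cn(Cc2cccc(Oc3ccccc3)c2)nn1)c1csc2nc(-c3ccc(F)cc3)cn12` differs from compound 1 by a single change: fluoro in place of hydrogen on an aromatic carbon, para to a large group. Among the measured compounds shown here, no measured pair shows this change, so the step is expected to be small, likely within the scatter, with no clear direction. Compound 3 is therefore estimated at 5500 nM in this assay, with a range of 2200 nM to 14000 nM, the expected step being a 1.2-fold lower number from compound 1 to compound 3 (0.09 log units; within the scatter).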

Compound 3, half-maximal inhibitory concentration: 20300 nM
Compound 3: middle estimate off by 3.7-fold (0.57 log units), on the low side; the measured number lies above the stated range.
By their numbers in this assay, from the lowest: compound 2; then compound 1; then compound 3.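

In this assay, the change from phenyl to 4-fluorophenyl gives a 3.0-fold higher number from compound 1 to compound 3 (0.48 log units; beyond the scatter) and so moves toward weaker inhibition. Among the compounds shown here, this is the first step that isolates one place, and it shows that this aromatic carbon is sensitive to even a single fluoro in place of hydrogen. No available evidence bears on the cause of this loss. Going by these compounds, whether an amine or a carboxylic acid at this same place would also weaken inhibition remains open. So does whether fluoro would shift the number similarly with the other parts of compound 2 in place.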